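A few compounds are considered here, and "the series" means these few. Any claim that something is new, unique, unknown or untested is made for them only; others in the source may bear on it.

Measured so far:
- Compound 1 `O=c1[nH]/c(=C\c2nc[nH]c2C2CC2)c(=O)[nH]/c1=C\c1cccc(Oc2ccc(F)cc2)c1`: 15.2 nM
- Compound 2 `O=c1[nH]/c(=C\c2ccco2)c(=O)[nH]/c1=C\c1cccc(Oc2ccc(F)cc2)c1`: 155 nM

In a functional assay on NCI-H460 cells (Homo sapiens) for cytotoxicity, read by MTT assay, with a stated time of 72 h (a lower number here means a stronger inhibitor, a higher number a weaker inhibitor), compound 2 stands at 155 nM, the higher of the two numbers and so the weaker inhibitor of the pair. Compound 3 `O=c1[nH]/c(=C\c2ccc(Cl)o2)c(=O)[nH]/c1=C\c1cccc(Oc2ccc(F)cc2)c1` keeps all of compound 2 except for one change: chloro in place of hydrogen on an aromatic carbon. The difference reads furan-2-yl to 5-chlorofuran-2-yl. For the measured compounds named here, only one measured step bears on it, and only indirectly. Replacing 5-cyclopropyl-1H-imidazol-4-yl with furan-2-yl gave a 10-fold higher number from compound 1 to compound 2 (1.01 log units; beyond the scatter), a large step showing that the number can move with the group at this place. Going by the values given here, no measured compound carries chloro, so the size of its step is not known. A small step is expected, leaning towards a lower number, and it may stay within the scatter. The expected step is a 1.6-fold lower number from compound 2 to compound 3 (0.19 log units; within the scatter). For compound 3 the estimate is 100 nM, with an expected range of 30 nM to 300 nM.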

Compound 3, half-maximal inhibitory concentration: 180 nM
The estimate for compound 3 lay 1.8-fold (0.26 log units) below the measured number; measured number inside the range.
By their numbers in this assay, from the lowest: compound 1; then compounds 2 and 3 (each within the scatter of the next).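

In this assay chloro in place of hydrogen, on the aromatic carbon next to the ring oxygen, gives a 1.2-fold higher number from compound 2 to compound 3 (0.06 log units; within the scatter) and so the two numbers cannot be told apart at this place. The large step away from compound 1 persists with the chloro group present, as 5-chlorofuran-2-yl in place of 5-cyclopropyl-1H-imidazol-4-yl gives a 12-fold higher number from compound 1 to compound 3 (1.07 log units; beyond the scatter) and shows that this one added atom does not close the gap. Nothing measured here gives a reason for either step.

From the compounds shown here alone, it remains open whether a methyl, a methoxy or an amine on the same ring carbon would match chloro. Also open, going by these compounds, is whether a 1H-imidazol-4-yl without the cyclopropyl would keep the low number of compound 1.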